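A methoxy swap at the limit of the assay

The source may hold more compounds than are shown below. What is called first, only, known or untested is meant among the compounds shown, and "the series" means these compounds.

In an ADME assay on GES1 cells (Homo sapiens) for inhibition, read by MTT assay, with a stated time of 72 h (on this read-out higher numbers stand for weaker inhibition and lower numbers for stronger inhibition), compound 1 `Cc1cc(Nc2cc(-c3ccccc3)[nH]n2)n2nc(SCc3cccc(Br)c3)nc2n1` reaches only a limit of the assay, > 50000 nM. Among the compounds with values here, compound 2 `Cc1cc(Nc2cc(-c3ccccc3)[nH]n2)n2nc(SCc3ccc(C(F)(F)F)cc3)nc2n1` gives 42700 nM, the only exact number so far. Within the data shown here, the one measured step, an at least 1.1-fold lower number from compound 1 to compound 2 (0.06 log units; that floor lies within the scatter), is only a floor and changed a different group. Compound 3 `COc1ccc(CSc2nc3nc(C)cc(Nc4cc(-c5ccccc5)[nH]n4)n3n2)cc1` differs from compound 2 by methoxy in place of trifluoromethyl on an aromatic carbon. Among the measured compounds shown here, no measured step bears directly on this change, so no shift beyond the scatter is expected, and a result reported only as a limit is possible. The expected change is a 1.1-fold higher number from compound 2 to compound 3 (0.02 log units; within the scatter). For compound 3 the estimated value is 45000 nM, within a range of 20000 nM to 90000 nM.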

Compound 3, half-maximal inhibitory concentration: 28200 nM
Compound 3: middle estimate off by 1.6-fold (0.20 log units), on the high side, and the stated range covers the measured number.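

In this assay this position now has a direct reading: methoxy in place of trifluoromethyl gives a 1.5-fold lower number from compound 2 to compound 3 (0.18 log units; within the scatter), so the two groups cannot be told apart here, although methoxy brings one hydrogen-bond acceptor and trifluoromethyl none. The other new comparison, an at least 1.7-fold lower number from compound 1 to compound 3 (0.24 log units; that floor lies within the scatter), is likewise only a floor. Its true size stays unknown because one partner sits at a limit: the limit of > 50000 nM in this assay, at which 1 of the 3 values shown sits.

Going by these compounds, whether an amine or a carboxylic acid at this position would move the number beyond the scatter remains open. Both groups shown here leave that question untested.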